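The source may hold more compounds than are shown below. What is called first, only, known or untested is meant among the compounds shown, and "the series" means these compounds.

Measured in a functional assay on MCF7 cells (Homo sapiens) for antiproliferative activity, read by MTT assay, with a stated time of 48 h; on this read-out lower numbers stand for stronger inhibition and higher numbers for weaker inhibition:

- compound 1 `COc1ccc(C(=O)c2ccc(OC)c3c2C=CC(C)(C)O3)c(NC(=O)CBr)c1`: 3290 nM
- compound 2 `COc1ccc(C(=O)c2ccc3c(c2)C=CC(C)(C)O3)c(NC(=O)CO)c1`: 200 nM

Compound 1 stands at the higher of these two numbers, and its gap to compound 2 lies beyond the scatter. The two compounds differ in more than one place, so that gap cannot be tied to a single change.

Compound 3 `COc1ccc(C(=O)c2ccc(OC)c3c2C=CC(C)(C)O3)c(NC(=O)CN(C)C)c1` has not yet been measured. It keeps the core of compound 1 and changes only the chain: dimethylamino in place of bromo on a saturated chain carbon bound to a carbonyl carbon. In words, dimethylamino stands in place of bromo on a saturated chain carbon bound to a carbonyl carbon. For the measured compounds named here, no measured pair shows this exchange, so any expectation remains loose. Going by the values given here, the only guide is that compound 2, which carries no bromo, reaches 200 nM. A moderate move towards a lower number is therefore expected in this assay, although a result within the scatter would be no surprise. The expected change is a 2.2-fold lower number from compound 1 to compound 3 (0.34 log units; beyond the scatter). Compound 3 is estimated at 1500 nM, with an expected range from 300 nM to 6000 nM.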

Compound 3, half-maximal inhibitory concentration: 6530 nM
Compound 3: the middle estimate sits 4.4-fold (0.64 log units) below what was measured, and the stated range ends below it.
By their numbers in this assay, from the lowest: compound 2; then compounds 1 and 3 (each within the scatter of the next).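

In this assay, for the compounds shown here, dimethylamino in place of bromo on a saturated chain carbon bound to a carbonyl carbon gives a 2.0-fold higher number from compound 1 to compound 3 (0.30 log units; within the scatter) and this is the first reading of a single change at this place. On the core of compound 1 the exchange puts three heavy atoms and one hydrogen-bond acceptor where one bromine stood, yet the numbers of the two compounds cannot be told apart in this assay, so the bromo group is not needed to keep the number at this level. No other measurement shown bears on this result.

Going by these compounds, whether a hydroxy group, a carboxylic acid, a primary amine or a longer chain on this saturated chain carbon would read differently on the core of compound 1 remains open. Compound 2 differs from compound 1 in more than one place, so the compounds shown leave open which of those differences goes with its lower number, and whether the same exchange of bromo for dimethylamino would read alike on the core of compound 2.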